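A few compounds are considered here, and "the series" means these few. Any claim that something is new, unique, unknown or untested is made for them only; others in the source may bear on it.

Measured so far in an ADME assay on Vero cells (Chlorocebus sabaeus) for cytotoxicity, read by resazurin assay, with a stated time of 3 days; a lower number here means a stronger inhibitor, a higher number a weaker inhibitor:

compound 1 `CCCc1ccc(C(=O)Nc2cc3nc(C4CCCCC4)[nH]c3cc2N(C)C)cc1` — > 100 ug/mL
compound 2 `CCCc1ccc(C(=O)Nc2cc3nc(C4CCCCC4)[nH]c3cc2N(CC)CC)cc1` — "not determined" (no result reported)
compound 3 `CCN(CC)c1cc2[nH]c(C3CCCCC3)nc2cc1NC(=O)c1cnccn1` — > 100 ug/mL

Compound 1 did not return a number in this assay but a limit, > 100 ug/mL. Compound 3 likewise sits at a limit of the assay, > 100 ug/mL. For compound 2 no result was reported, "not determined" (no result reported). Compound 1 therefore stands at the position shared by two of the three entries, (the limit of > 100 ug/mL in this assay, at which 2 of the 3 values shown sit), and no single number is available for any measured compound.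

Compound 4 `CN(C)c1cc2[nH]c(C3CCCCC3)nc2cc1NC(=O)c1ccc(OC(F)F)cc1` has not yet been measured in this assay. It differs from compound 1 in one place: difluoromethoxy in place of propyl on an aromatic carbon. For the measured compounds named here, no step between measured compounds is available to gauge this change, so the size of the step has to be expected rather than read off. Given that two of the three values sit at the limit of > 100 ug/mL in this assay, at which 2 of the 3 values shown sit, the expectation is a step no larger than the usual scatter, with the result again most likely returned as a limit rather than a number.

Compound 4 is expected to give 100 ug/mL, between 50 ug/mL and 200 ug/mL, a step of a number no higher from compound 1 to compound 4 (the limit leaves the size open) that is expected to stay within the scatter.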

Compound 4, half-maximal inhibitory concentration: > 100 ug/mL
Compound 4: no number, only a limit (the forecaster's own chance of this, stated with the estimate: 80%); the middle value sits exactly at the limit.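

In this assay compound 4 gives > 100 ug/mL as a limit, not a number. For the compounds shown here, compound 1 likewise gives > 100 ug/mL as a limit, so no step between the two can be read. The compounds shown leave open whether difluoromethoxy in place of propyl changes the value at all, as most entries rest at one position: the limit of > 100 ug/mL in this assay, at which 3 of the 4 values shown sit.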